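Swapping bromo for chloro on a compound at the limit

The source may report more compounds than this note shows. Statements on the series, on what has been measured and on what is new or still open speak of the compounds shown alone.

In a toxicity assay on THP-1 cells (Homo sapiens) for inhibition (on this read-out higher numbers stand for lower toxicity in this test and lower numbers for higher toxicity in this test), compound 1 (`COc1ccc(-c2cnc(NC(=O)c3ccc(F)cc3)n2C)cc1`) gives >= 50000 nM, which is a limit of the assay and not a number. Compound 2 (`Cn1c(-c2cccc(Br)c2)cnc1NC(=O)c1ccc(F)cc1`) gives > 50000 nM, and this too is only a limit. Neither compound therefore has a readable value, and compound 2 can be placed only by its limit.

The next compound, compound 3 (`Cn1c(-c2cccc(Cl)c2)cnc1NC(=O)c1ccc(F)cc1`), has chloro in place of bromo on an aromatic carbon, meta to a large group: chloro in place of bromo on an aromatic carbon. Going by the values given here, the only measured step that bears on this change is a step that the two limits leave unreadable from compound 1 to compound 2. It involves a different exchange on the same ring, and it gives no size to carry over. What remains is that both measured compounds reach a limit in this assay, and the exchange of one halogen for another is small in the counted terms.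

The expected outcome is a number no higher from compound 2 to compound 3 (the limit leaves the size open), meaning no step beyond the usual scatter, and quite probably another reading reported only as a limit. The estimate for compound 3 is 50000 nM, with an expected range from 30000 nM to 80000 nM.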

Compound 3, half-maximal cytotoxic concentration: > 50000 nM
Compound 3 gave a limit, no number; the forecaster's own chance of this, stated with the estimate: 85%; the middle value lies on the limit itself.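

Compound 3 gives > 50000 nM in this assay, which is a limit of the assay and not a number. Going by these compounds alone, as compound 1 and compound 2 also stand only at limits, no step among the three compounds can be read. The compounds shown leave open where their actual values lie, and so whether chloro and bromo differ at all here.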